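This account rests on a few compounds, and the source may have more. Where it says the series, first, only, none or still open, it means among the compounds named here.

Compound 1 `ClCc1ccc(Cn2cnc3c(Cl)ncnc32)cc1`: in a functional assay on HT-29 cells (Homo sapiens) for cytotoxicity, read by sulforhodamine B assay, with a stated time of 48 h (on this read-out higher numbers stand for weaker inhibition of growth and lower numbers for stronger inhibition of growth), compound 1 gives "not determined" (no result reported).
Compound 2 `ClCc1ccccc1Cn1cnc2c(Cl)ncnc21`: in this assay compound 2 gives 3540 nM.
Compound 3 `ClCc1cccc(Cn2cnc3ncnc(Cl)c32)c1`: in this assay compound 3 gives 2880 nM.

Compound 3 holds the lowest of the two numbers shown, but its nearest neighbour, compound 2, sits within the scatter of it, so the two cannot be set in order. Compound 1 adds nothing to the picture, as no number is reported for it. Among the measured compounds shown here, no two measured compounds differ in a single place, so no step has been measured.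

Compound 4 `ClCc1cccc(Cn2cnc3nc(Cl)nc(Cl)c32)c1` differs from compound 3 in one place: chloro in place of hydrogen on an aromatic carbon. For the measured compounds named here, with no measured step to lean on, the account can only reason from the single number of compound 3 and from the small size of the change. The expectation is a step of a 1.2-fold lower number from compound 3 to compound 4 (0.06 log units; within the scatter), no farther than the usual scatter, in either direction. Compound 4 is therefore estimated at 2500 nM, with a plausible range from 900 nM to 7000 nM.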

Compound 4, concentration for 50% growth inhibition: 340 nM
Estimate against measurement, compound 4: 7.4-fold (0.87 log units) above; measured number outside the range, below it.
By their numbers in this assay, from the lowest: compound 4; then compounds 3 and 2 (each within the scatter of the next).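

In this assay, chloro in place of hydrogen on the aromatic carbon between two ring nitrogen atoms brings an 8.5-fold lower number from compound 3 to compound 4 (0.93 log units; beyond the scatter) and so shows that this position of the shared core can change growth inhibition by more than the usual scatter. The earlier compounds shown here could not show this, since no two of them differ in a single place and compound 2 and compound 3 lie within the scatter of each other. Nothing at hand bears on why this single atom makes such a step.

From the compounds shown here alone, only hydrogen and chloro are seen at this position, so it stays open whether an amine, a methoxy group or a fluoro group there would give a similar step. Going by these compounds, it also stays open whether the chloro step would carry over to the core of compound 2.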